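Tolerance of Four Related Compounds in Liver Cells

A few compounds are considered here, and "the series" means these few. Any claim that something is new, unique, unknown or untested is made for them only; others in the source may bear on it.

Compound 1 `COc1cc(O)c(C(=O)/C=C/c2ccc(OC)c(OCc3cn(-c4ccccc4Cl)nn3)c2)c(OC)c1` was examined in an ADME assay on Huh-7 cells (Homo sapiens) for cytotoxicity, read by MTT assay, with a stated time of 72 h; a higher number here means that more compound is tolerated, a lower number that less compound is tolerated. In this assay compound 1 gives > 100 ug/mL, which is a limit of the assay and not a number. Compound 2 `COc1cc(O)c(C(=O)/C=C/c2ccc(OC)c(OCc3cn(-c4ccc(F)c(Cl)c4)nn3)c2)c(OC)c1` differs from compound 1 by 3-chloro-4-fluorophenyl in place of 2-chlorophenyl on an aromatic nitrogen. In this assay compound 2 gives > 100 ug/mL, again a limit rather than a number. The step is therefore a step that the two limits leave unreadable from compound 1 to compound 2, and the limit of > 100 ug/mL in this assay, at which 3 of the 3 values shown sit, is what keeps its size hidden. Compound 3 `COc1cc(O)c(C(=O)/C=C/c2ccc(OCc3cn(-c4ccccc4Cl)nn3)c(OC)c2)c(OC)c1` is built from the same atoms as compound 1 joined differently; the difference between the two cores is not broken down here. In this assay compound 3 gives > 100 ug/mL, once more a limit of the assay. Compound 4 `COc1cc(O)c(C(=O)/C=C/c2ccc(OCc3cn(-c4ccc(F)c(Cl)c4)nn3)c(OC)c2)c(OC)c1` is not yet measured and differs from compound 3 by 3-chloro-4-fluorophenyl in place of 2-chlorophenyl on an aromatic nitrogen, the same change that carries compound 1 to compound 2. Because (the limit of > 100 ug/mL in this assay, at which 3 of the 3 values shown sit), the step from compound 3 to compound 4 is expected to be a number no higher from compound 3 to compound 4 (the limit leaves the size open). Compound 4 is accordingly estimated at 100 ug/mL, expected to fall between 60 ug/mL and 160 ug/mL.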

Compound 4, half-maximal cytotoxic concentration: > 100 ug/mL
Compound 4 ended at the assay's limit (the forecaster's own chance of this, stated with the estimate: 85%); the middle value lies on the limit itself.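

No size can be read for the step between compound 3 and compound 4, so this result adds no new step, and the reason is: the limit of > 100 ug/mL in this assay, at which 4 of the 4 values shown sit.

The compounds shown leave open whether 3-chloro-4-fluorophenyl in place of 2-chlorophenyl, or the difference between the two cores, changes tolerance in this assay at all.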